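A few compounds are considered here, and "the series" means these few. Any claim that something is new, unique, unknown or untested is made for them only; others in the source may bear on it.

In a functional assay on HepG2 cells (Homo sapiens) for cytotoxicity, read by MTT assay, with a stated time of 48 h (a lower number here means a stronger inhibitor, a higher number a weaker inhibitor), compound 1 `COc1ccc(/C=N/NC(=O)CSc2nnc(-c3ccncc3)o2)cc1` gives 15800 nM, compound 2 `O=C(CSc1nnc(-c2ccncc2)o1)N/N=C/c1cc(Cl)cc(Cl)c1O` gives 3260 nM, and compound 3 `O=C(CSc1nnc(-c2ccncc2)o1)N/N=C/c1cc(Br)cc(Br)c1O` gives 6540 nM. Compound 3 therefore stands with compound 2 at the lower level of these numbers, since the data show a 2.0-fold higher number from compound 2 to compound 3 (0.30 log units; within the scatter). Compound 1 stands apart, with a 2.4-fold lower number from compound 1 to compound 3 (0.38 log units; beyond the scatter) and a 4.8-fold lower number from compound 1 to compound 2 (0.69 log units; beyond the scatter).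

The next structure is compound 4 `O=C(CSc1nnc(-c2ccncc2)o1)N/N=C/c1cccs1`, which changes the group on a carbon with a double bond to nitrogen: thiophen-2-yl in place of 3,5-dibromo-2-hydroxyphenyl on a carbon with a double bond to nitrogen. Among the compounds with values here, no measured compound carries thiophen-2-yl, so the data offer no direct precedent. The closest guide is that, like compound 4, compound 1 has neither bromine nor a hydroxy group, and compound 1 gives 15800 nM. The modest steps from it to the two halogenated compounds suggest that losing the 3,5-dibromo-2-hydroxyphenyl group could reverse part of that drop. A modest rise in this assay is therefore expected, though it may not clear the scatter. The estimated change is a 2.0-fold higher number from compound 3 to compound 4 (0.30 log units; within the scatter). For compound 4 the expected value is 13000 nM, with an estimated range from 5000 nM to 32000 nM.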

Compound 4, half-maximal inhibitory concentration: 14900 nM
Estimate against measurement, compound 4: 1.1-fold (0.06 log units) below; low and high end bracket the measured number.
By their numbers in this assay, from the lowest: compounds 2 and 3 (each within the scatter of the next); then compounds 4 and 1 (each within the scatter of the next).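

In this assay, thiophen-2-yl on the carbon with a double bond to nitrogen shows that a five-membered aromatic ring containing sulfur gives a reading level with that of the 4-methoxyphenyl group (a 1.1-fold lower number from compound 1 to compound 4 (0.03 log units; within the scatter)). The two groups carrying both halogen and hydroxy now stand apart from this new group, for bromine (a 2.3-fold higher number from compound 3 to compound 4 (0.36 log units; beyond the scatter)) and for chlorine (a 4.6-fold higher number from compound 2 to compound 4 (0.66 log units; beyond the scatter)). Among these four compounds, two different groups lacking halogen and hydroxy thus share one level, and the lower numbers belong only to compounds 2 and 3. Still open, as far as these compounds go, is whether the hydroxy group or the halogens go with those lower numbers, and a plain 2-hydroxyphenyl or 3,5-dichlorophenyl group here would separate the two. No measurement at hand explains why these numbers differ.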